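The source may report more compounds than this note shows. Statements on the series, on what has been measured and on what is new or still open speak of the compounds shown alone.

Measured so far in an ADME assay on Huh-7 cells (Homo sapiens) for cytotoxicity; a higher number here means that more compound is tolerated, a lower number that less compound is tolerated:
Compound 1, `Cc1ccccc1-c1nn(-c2ccc(C(F)(F)F)cc2)cc1CNCCN1CCN(C)CC1`, gives 11000 nM.
Compound 2, `COc1ccc(-n2cc(CNCCN3CCN(C)CC3)c(-c3ccccc3C)n2)cc1`, gives > 20000 nM, which is a limit of the assay and not a number.
Compound 3, `CN1CCN(CCCNCc2cn(-c3ccc([N+](=O)[O-])cc3)nc2-c2ccc(C(F)(F)F)cc2)CC1`, gives 4900 nM.

Compound 2 therefore stands at the top of the numbers shown, at the limit of > 20000 nM in this assay, at which 1 of the 3 values shown sits; only a limit is known for it. Among the measured compounds shown here, the single measured step, an at least 1.8-fold higher number from compound 1 to compound 2 (0.25 log units; that floor lies within the scatter), concerns methoxy in place of trifluoromethyl on an aromatic carbon and ends at that limit. Compound 4, `CCOC(=O)Cn1cc(CNCCN2CCN(C)CC2)c(-c2ccccc2C)n1`, differs from compound 2 by (ethoxycarbonyl)methyl in place of 4-methoxyphenyl on an aromatic nitrogen. No measured step involves a group on the aromatic nitrogen, so nothing shown bears directly on this change, and the expectation rests on compound 2 alone. Compound 4 is estimated at 15000 nM, with a range of 6000 nM to 30000 nM, and the expected step of an at least 1.3-fold lower number from compound 2 to compound 4 (0.12 log units; that floor lies within the scatter) is taken to stay within the scatter.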

Compound 4, half-maximal cytotoxic concentration: > 20000 nM
Compound 4 gave a limit, no number (the forecaster's own chance of this, stated with the estimate: 45%); at least 1.3-fold (0.12 log units) between middle value and limit.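

The aromatic nitrogen now carries a group with no ring, (ethoxycarbonyl)methyl, and in this assay the change from 4-(trifluoromethyl)phenyl gives an at least 1.8-fold higher number from compound 1 to compound 4 (0.25 log units; that floor lies within the scatter). An aryl group on this nitrogen is therefore not needed to reach the top of the assay's range. Compound 2 and compound 4 both end at a limit, so the step between them cannot be read: the limit of > 20000 nM in this assay, at which 2 of the 4 values shown sit.

As far as these compounds go, how far either compound lies past that limit remains open. Also open, from the compounds shown here alone, is whether a carboxylic acid, a primary amide or a longer alkyl chain in place of (ethoxycarbonyl)methyl would stay at the limit.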